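The compounds below may be only part of what the source reports. "The series", "measured", "known", "first", "only" and "open" are said of these compounds alone.

Measured so far in a functional assay for activation of Alpha-1B adrenergic receptor (Homo sapiens), read by calcium flux; a lower number here means that less compound is needed, a higher number that more compound is needed for the effect:
compound 1 `c1coc(-c2ccccc2NCC2=NCCN2)c1`, 6.31 nM
compound 2 `Cc1nc(-c2ccccc2NCC2=NCCN2)cs1`, 69.2 nM
compound 3 `Cc1noc(-c2ccccc2NCC2=NCCN2)n1`, < 5020 nM, which is a limit of this assay and not a number.

Compound 3 thus stands only at the limit (the limit of < 5020 nM in this assay, at which 1 of the 3 values shown sits), with no readable number. Compound 4 `Cc1ccc(-c2ccccc2NCC2=NCCN2)o1` differs from it by 5-methylfuran-2-yl in place of 3-methyl-1,2,4-oxadiazol-5-yl on an aromatic carbon. Going by the values given here, two measured steps touch compound 3, a step that the limit leaves unreadable from compound 1 to compound 3 and a step that the limit leaves unreadable from compound 2 to compound 3, and both end at the limit without a size. Among the compounds with values here, the one readable step, an 11-fold higher number from compound 1 to compound 2 (1.04 log units; beyond the scatter), shows that exchanging the five-membered ring moves this assay widely. Compound 4 carries a ring of the same kind as compound 1, and compound 1 gives 6.31 nM. Compound 4 is therefore expected near that value, at 10 nM, between 3 nM and 40 nM, an expected step that the limit leaves unreadable from compound 3 to compound 4 down from the limit of compound 3.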

Compound 4, half-maximal effective concentration: 46.8 nM
The estimate for compound 4 lay 4.7-fold (0.67 log units) below the measured number; the measured number lies above the stated range.
By their numbers in this assay, from the lowest: compound 1; then compounds 4 and 2 (each within the scatter of the next).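

In this assay, methyl on the furan ring is not a silent change at this position, with a 7.4-fold higher number from compound 1 to compound 4 (0.87 log units; beyond the scatter). The two methylated rings, 5-methylfuran-2-yl and 2-methyl-1,3-thiazol-4-yl, are not separated here, with a 1.5-fold lower number from compound 2 to compound 4 (0.17 log units; within the scatter). The steps to compound 3 cannot be read, because its value is a limit and not a number: the limit of < 5020 nM in this assay, at which 1 of the 4 values shown sits.

On the furan ring only hydrogen and methyl are shown, which leaves open how an ethyl, a methoxy or an amine group there would read. From the compounds shown here alone, whether the thiazole ring without its methyl would follow the furan pair also remains open.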